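Chloro in Place of Methoxy: Expected Paw Edema Inhibition

A few compounds are considered here, and "the series" means these few. Any claim that something is new, unique, unknown or untested is made for them only; others in the source may bear on it.

Measured so far:
compound 1, `COc1ccc(/C=C/C(=O)c2ccc3c(c2)CN(c2ccc(OC)cc2)CO3)cc1`, in a functional assay on the whole organism (strain Wistar) for inhibition, with Rattus norvegicus as the target, read by paw edema, with a stated time of 3 h, at a dose of 20 mg/kg by the oral route (on this read-out lower numbers stand for less inhibition and higher numbers for more inhibition at the one dose given (going by the name of the read-out)), compound 1 gives 61.2%
compound 2, `COc1ccc(N2COc3ccc(C(=O)/C=C/c4cc(OC)c(OC)c(OC)c4)cc3C2)cc1`, in this assay compound 2 gives 62.2%

The two numbers of compound 1 and compound 2 lie within the usual scatter of each other, so neither can be set apart from the other on these data; compound 1 simply carries the smaller of the two figures.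

Compound 3, `COc1ccc(N2COc3ccc(C(=O)/C=C/c4ccc(Cl)cc4)cc3C2)cc1`, has not yet been measured. It differs from compound 1 in one place: chloro in place of methoxy on an aromatic carbon. Among the compounds with values here, no pair of measured compounds shows this exchange, so the step has no precedent here. The expectation is that the step from compound 1 to compound 3 in this assay stays within the scatter, with no clear direction. Compound 3 is therefore estimated at 58%, with a range from 45% to 70%. This estimate means an expected step of a number 3.2 percentage points lower from compound 1 to compound 3 (within the scatter).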

Compound 3, a percentage reported as inhibition, in the whole organism at one dose (the size of the read-out at that dose, not a potency): 67.4%
The estimate for compound 3 lay 9.4 percentage points below the measured number; the range from low to high includes it.
By their numbers in this assay, from the lowest: compounds 1, 2 and 3 (each within the scatter of the next).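

In this assay, chloro in place of methoxy on the aromatic carbon para to a large group gives a number 6.2 percentage points higher from compound 1 to compound 3 (within the scatter). Within the data shown here, this is the first reading of this exchange, and it shows that the methoxy group is not needed at this place for the paw edema read-out to stay within the scatter of compound 1. On these numbers, the 4-chlorophenyl and 4-methoxyphenyl forms cannot be told apart, and nothing measured here speaks to why that is so.

The compounds shown leave open whether an amine, a carboxylic acid or a bromo group at this same place would also stay within that scatter. They also leave open whether compound 1 and compound 3 would still read alike at other doses or at other times.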